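Catechol Replaces Chloroaryl in a Bis-arylidene Cyclohexanone Series

The compounds below may be only part of what the source reports. "The series", "measured", "known", "first", "only" and "open" are said of these compounds alone.

Three analogues sharing one core have been measured in a functional assay on SW-620 cells (Homo sapiens) for cytotoxicity, read by MTT assay, with a stated time of 72 h; on this read-out lower numbers stand for stronger inhibition and higher numbers for weaker inhibition. Compound 1 `COc1cccc(/C=C2\CCC/C(=C\c3ccc(Cl)cc3)C2=O)c1OC` gives 11100 nM, the highest number of the three, while compound 2 `COc1cccc(/C=C2\CCC/C(=C\c3cccc(Br)c3)C2=O)c1OC` gives 8800 nM and compound 3 `COc1cccc(/C=C2\CCC/C(=C\c3ccc(Cl)c(Cl)c3)C2=O)c1OC` gives 10000 nM. Each pairwise step stays within the scatter: a 1.3-fold lower number from compound 1 to compound 2 (0.10 log units; within the scatter), a 1.1-fold lower number from compound 1 to compound 3 (0.05 log units; within the scatter) and a 1.1-fold higher number from compound 2 to compound 3 (0.06 log units; within the scatter). Exchanging one halogen pattern on the arylidene ring for another therefore leaves this assay essentially unmoved.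

Compound 4 `COc1cccc(/C=C2\CCC/C(=C\c3ccc(O)c(O)c3)C2=O)c1OC` departs from compound 1 by a different kind of change: 3,4-dihydroxyphenyl in place of 4-chlorophenyl on a double-bonded chain carbon bound to a double-bonded ring carbon. Among the measured compounds shown here, no measured step covers a move from a halogenated aryl to a dihydroxyphenyl group, so the expectation rests on the observation that the three measured compounds cluster tightly and that the core itself seems to carry the activity. The new group brings hydrogen-bond donors and acceptors that the measured set lacks, which widens the uncertainty in both directions.

Compound 4 is estimated at 8000 nM, with a range from 2500 nM to 25000 nM, corresponding to an expected step of a 1.4-fold lower number from compound 1 to compound 4 (0.14 log units; within the scatter).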

Compound 4, half-maximal inhibitory concentration: 6300 nM
Beside the measured number, compound 4's estimate is 1.3-fold (0.10 log units) above it; the measured number falls inside the stated range.
By their numbers in this assay, from the lowest: compounds 4, 2, 3 and 1 (each within the scatter of the next).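

In this assay, this position accepts 3,4-dihydroxyphenyl, which brings hydrogen-bond donors and acceptors, with no step beyond the scatter: the three steps read (a 1.8-fold lower number from compound 1 to compound 4 (0.25 log units; within the scatter)), (a 1.6-fold lower number from compound 3 to compound 4 (0.20 log units; within the scatter)) and (a 1.4-fold lower number from compound 2 to compound 4 (0.15 log units; within the scatter)). The flat read-out seen among the halogenated aryl groups therefore extends to a group of a different kind, and none of the four compounds separates from the others. No available evidence bears on this result.

As far as these compounds go, whether an amine or a carboxylic acid on this ring, or a single hydroxyl in place of the two, would move the number beyond the scatter remains open. The other aryl group of the shared core is the same in all four compounds, so the effect of changing it is also unknown.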